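The compounds below may be only part of what the source reports. "The series", "measured", "known", "first", "only" and "open" are said of these compounds alone.

Measured so far:
- compound 1, `CC(=O)c1c(O)cc(O)cc1CCCCCCCCc1ccccc1`: 3.89 ug/mL
- compound 2, `CCCCCCCCCCCCCc1cc(O)cc(O)c1C(C)=O`: 2.3 ug/mL

Both numbers come from a functional assay on A549 cells (Homo sapiens) for cytotoxicity, with a stated time of 7 days; on this read-out higher numbers stand for an effect only at larger amounts of compound and lower numbers for an effect already at smaller amounts. Compound 2 carries the lowest of the two numbers, with compound 1 as its nearest neighbour; the separation between them is the step of a 1.7-fold lower number from compound 1 to compound 2 (0.23 log units; within the scatter), which does not exceed the scatter, so no order between the two compounds can be claimed.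

The next compound is compound 3, `CC(=O)c1c(O)cc(O)cc1CCCCCCCCCCc1ccccc1`. Compared with compound 2 the change is phenyl in place of propyl on a saturated chain carbon, ten or more bonds along the chain from an aromatic carbon.

Among the compounds with values here, the only measured step that bears on this is a 1.7-fold lower number from compound 1 to compound 2 (0.23 log units; within the scatter), in which an alkyl group replaced a ring at the chain end without moving the number beyond the scatter. The change from compound 2 to compound 3 runs the other way, a ring entering for an alkyl group, and sits further out along the chain. On this basis the step from compound 2 to compound 3 in this assay is expected to be small, a 1.3-fold higher number from compound 2 to compound 3 (0.12 log units; within the scatter), with no direction beyond the scatter. The value for compound 3 in this assay is therefore estimated at 3 ug/mL, within 1.5 ug/mL to 6 ug/mL.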

Compound 3, concentration for half-maximal effect: 3.22 ug/mL
Compound 3: middle estimate off by 1.1-fold (0.03 log units), on the low side, within the range that was stated.
By their numbers in this assay, from the lowest: compounds 2, 3 and 1 (each within the scatter of the next).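

At the far end of the chain, phenyl in place of propyl leaves this assay without a readable separation (a 1.4-fold higher number from compound 2 to compound 3 (0.15 log units; within the scatter)), so the ring-for-alkyl exchange is now seen at a second place and chain length, and again stays within the scatter. Within the data shown here, compound 3 also gives the first comparison with a ring kept at the chain end: phenethyl in place of phenyl, on a saturated chain carbon eight bonds along the chain from an aromatic carbon, likewise stays within the scatter (a 1.2-fold lower number from compound 1 to compound 3 (0.08 log units; within the scatter)), so compounds 1, 2 and 3 cannot be ordered and this end of the chain shows no preference between a terminal phenyl and a plain alkyl end across these three compounds; nothing available explains this flatness.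

As far as these compounds go, whether an amine or a carboxylic acid at the chain end, or a much shorter chain, would move the number beyond the scatter stays open. Equally open, from the compounds shown here alone, is how much the shared core itself contributes, for instance on replacing the acetyl group or a hydroxyl group, since all three compounds keep it unchanged.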